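A new group on the amide-type nitrogen

The source may hold more compounds than are shown below. What is called first, only, known or untested is meant among the compounds shown, and "the series" means these compounds.

In a physicochemical assay for solubility, measured as kinetic solubility (a higher number here means a more soluble compound, a lower number a less soluble compound), compound 3 (`CCC/N=C1\S/C(=C\c2ccc(O)c(Cl)c2)C(=O)N1C1CCOCC1`) gives 70000 nM. That value lies within the scatter of compound 1 (`CCC/N=C1\S/C(=C\c2ccc(O)cn2)C(=O)N1c1ccccc1C`) at 110000 nM and of compound 2 (`CCC/N=C1\S/C(=C\c2ccc(O)cc2)C(=O)N1c1ccccc1C`) at 79000 nM.

Compound 4 (`CCC/N=C1\S/C(=C\c2ccc(O)c(Cl)c2)C(=O)N1c1ccccc1O`) differs from compound 3 in one place: 2-hydroxyphenyl in place of oxan-4-yl on an amide-type nitrogen in a ring. In short, 2-hydroxyphenyl stands in place of oxan-4-yl on an amide-type nitrogen in a ring.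

Among the compounds with values here, the only measured single-place step is a 1.4-fold lower number from compound 1 to compound 2 (0.14 log units; within the scatter). It puts 4-hydroxyphenyl in place of 5-hydroxypyridin-2-yl on a double-bonded chain carbon, not on that nitrogen, so it bears on the new change only indirectly. Within the data shown here, no measured step gives a direct size for the change at the nitrogen. Among the measured compounds shown here, with only that indirect guide, no shift beyond the scatter is expected in this assay, and the direction stays open. The expected step is a 1.3-fold lower number from compound 3 to compound 4 (0.10 log units; within the scatter). For compound 4 the estimate is 55000 nM, with an expected range of 18000 nM to 120000 nM.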

Compound 4, solubility: 220000 nM
Compound 4: the middle estimate sits 4.0-fold (0.60 log units) below what was measured; measured number above the stated range.
By their numbers in this assay, from the lowest: compounds 3, 2, 1 and 4 (each within the scatter of the next, the first and the last beyond it).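

Swapping oxan-4-yl for 2-hydroxyphenyl on the amide-type nitrogen in a ring gives a 3.1-fold higher number from compound 3 to compound 4 (0.50 log units; beyond the scatter) in this assay, so a single change at this position can move the number beyond the scatter. Within the data shown here, the only earlier step, a 1.4-fold lower number from compound 1 to compound 2 (0.14 log units; within the scatter), lay on a double-bonded chain carbon and did not show this. Nothing available explains the rise, and the data give no measured property of either group that bears on it.

Compounds 1 and 2 carry a different aromatic group on this nitrogen but also differ from compound 4 elsewhere, so they cannot show whether the hydroxyl or the aromatic ring carries the step. A plain phenyl or a 2-methoxyphenyl on the same nitrogen, with the rest of compound 4 unchanged, would separate the two.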